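Swapping the alkenyl arm for a chlorinated ring

The source may hold more compounds than are shown below. What is called first, only, known or untested is meant among the compounds shown, and "the series" means these compounds.

Of the compounds shown here, three built on a shared naphthoquinone-like core have been tested in a functional assay on WHCO1 cells (Homo sapiens) for cytotoxicity, read by MTT assay, with a stated time of 24 h; on this read-out higher numbers stand for weaker inhibition and lower numbers for stronger inhibition. Compound 1 `CC(C)=CC(O)C1=CC(=O)c2ccccc2C1=O` carries a 2-methylprop-1-en-1-yl group on a chain carbon that also bears a hydroxyl. In this assay compound 1 gives 5200 nM, the lowest number of the three. Compound 2 `Cc1cc(Cl)ccc1C(=O)C1=CC(=O)c2ccccc2C1=O`, which instead attaches an aromatic ring through a carbonyl, gives 50400 nM, and compound 3 `O=C(C1=CC(=O)c2ccccc2C1=O)c1ccc(F)cc1`, with a fluorinated ring on a carbonyl, gives 74900 nM. Both gaps to compound 1 lie beyond the usual scatter, so compound 1 is the strongest inhibitor among them.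

Compound 4 `O=C1C=C(C(O)c2cccc(Cl)c2)C(=O)c2ccccc21` has not yet been measured. It differs from compound 1 in one place: 3-chlorophenyl in place of 2-methylprop-1-en-1-yl on a saturated chain carbon bound to a double-bonded ring carbon and an oxygen on a saturated carbon. The hydroxyl on the chain carbon is kept; only the group beside it changes. Compounds 2 and 3 differ from compound 1 in two places at once, so they cannot tell directly what this single change does; they only show that the aryl-bearing ketones are weaker than compound 1.

Compound 4 is expected to be somewhat weaker than compound 1, with a step of a 1.9-fold higher number from compound 1 to compound 4 (0.28 log units; within the scatter) that may or may not exceed the scatter. The estimate for compound 4 in this assay is 10000 nM, within a range from 3000 nM to 40000 nM.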

Compound 4, half-maximal inhibitory concentration: 7300 nM
For compound 4 the middle estimate is 1.4-fold (0.14 log units) above the measured one; the range from low to high includes it.
By their numbers in this assay, from the lowest: compounds 1 and 4 (each within the scatter of the next); then compounds 2 and 3 (each within the scatter of the next).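

In this assay, putting 3-chlorophenyl in place of 2-methylprop-1-en-1-yl on the chain carbon that bears the hydroxyl gives a 1.4-fold higher number from compound 1 to compound 4 (0.15 log units; within the scatter). Among these compounds, this is the first single change at this place: a group of 7 heavy atoms with an aromatic ring stands where a group of 4 carbon atoms with no ring stood, and the two compounds cannot be told apart on this read-out, something compounds 2 and 3 could not show, as each differs from compound 1 in two places at once. No measurement shown here offers a reason for this match.

From the compounds shown here alone, what a plain phenyl group, an amine or a longer chain would give at this place remains open, as does the part played by the hydroxyl, which compound 1 and compound 4 share. All of this rests on this assay alone, so whether the two groups also read alike in other cells stays an open question.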